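The compounds below may be only part of what the source reports. "The series", "measured", "known", "first", "only" and "open" are said of these compounds alone.

In an assay on CHO cells for displacement of a labelled ligand from prostaglandin D2 receptor 2 (Homo sapiens), read by scintillation counting (a higher number here means a weaker inhibitor, a lower number a stronger inhibitor), three members of the series carry a sulfonyl group on the shared core, and only the substituent on the sulfonyl sulfur varies. Compound 1 `Cc1ccc(S(=O)(=O)N2CCCCC2C)cc1C#Cc1cc(Cl)ccc1OCC(=O)O` gives 1.9 nM, compound 2 `Cc1ccc(S(=O)(=O)CC(C)C)cc1C#Cc1cc(Cl)ccc1OCC(=O)O` gives 3 nM, and compound 3 `Cc1ccc(S(=O)(=O)N(C)C)cc1C#Cc1cc(Cl)ccc1OCC(=O)O` gives 5 nM. Compound 3 thus has the highest number of the three: the step of a 1.7-fold higher number from compound 2 to compound 3 (0.22 log units; within the scatter) lies within the scatter, while the step of a 2.6-fold higher number from compound 1 to compound 3 (0.42 log units; beyond the scatter) lies beyond it. Compound 4 `CCN(CC)S(=O)(=O)c1ccc(C)c(C#Cc2cc(Cl)ccc2OCC(=O)O)c1` differs from compound 3 by diethylamino in place of dimethylamino on a sulfonyl sulfur. Within the data shown here, two measured steps bear on this change, both ending at compound 3: a 2.6-fold higher number from compound 1 to compound 3 (0.42 log units; beyond the scatter) and a 1.7-fold higher number from compound 2 to compound 3 (0.22 log units; within the scatter). Both replace a larger substituent on the sulfonyl sulfur with dimethylamino, and both give higher numbers, though only the first lies beyond the scatter. Diethylamino is again the larger substituent, so a modest move back towards lower numbers is expected, roughly the reverse of a 1.7-fold higher number from compound 2 to compound 3 (0.22 log units; within the scatter). Compound 4 is therefore estimated at 3 nM, with a range from 1.5 nM to 7 nM. The expected step is a 1.7-fold lower number from compound 3 to compound 4 (0.22 log units; within the scatter).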

Compound 4, inhibition constant: 3.4 nM
Compound 4: the middle estimate sits 1.1-fold (0.05 log units) below what was measured; the range from low to high includes it.
By their numbers in this assay, from the lowest: compounds 1, 2, 4 and 3 (each within the scatter of the next, the first and the last beyond it).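

Replacing dimethylamino with diethylamino on a sulfonyl sulfur gives a 1.5-fold lower number from compound 3 to compound 4 (0.17 log units; within the scatter), so this added length on the nitrogen produces no change that can be separated from the scatter. Compound 4 also cannot be separated from the two other larger substituents, with a 1.1-fold higher number from compound 2 to compound 4 (0.05 log units; within the scatter) and a 1.8-fold higher number from compound 1 to compound 4 (0.25 log units; within the scatter), which places the open-chain diethylamino, the carbon-linked isobutyl and the ring-bearing 2-methylpiperidin-1-yl together at this position. No supporting data explain these small differences.

As far as these compounds go, whether a longer chain such as dipropylamino stays in this range remains open. So does the effect of placing a polar group on the sulfonyl sulfur, such as a morpholin-4-yl ring or a hydroxyethyl-bearing amine.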